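Changing one group on a weakly active compound

The source may hold more compounds than are shown below. What is called first, only, known or untested is meant among the compounds shown, and "the series" means these compounds.

- Compound 1 `CC(=O)c1ccc(-n2cc(COc3ccc(/C=C/C(=O)c4cc5c(cc4O)OC(C)(C)CC5)cc3)nn2)cc1` gives 182000 nM in a functional assay on MCF7 cells (Homo sapiens) for antiproliferative activity, read by MTT assay (on this read-out lower numbers stand for stronger inhibition and higher numbers for weaker inhibition), as its result
- Compound 2 `Cc1ccc(-n2cc(COc3ccc(/C=C/C(=O)c4cc5c(cc4O)OC(C)(C)CC5)cc3)nn2)cc1Br` gives "not active" (no number reported) in this assay with no number reported

As far as these compounds go, compound 2 has no single number on this read-out, so its exact standing is unknown. The change to compound 3 `CC1(C)CCc2cc(C(=O)/C=C/c3ccc(OCc4cn(Cc5ccc([N+](=O)[O-])cc5)nn4)cc3)c(O)cc2O1` is 4-nitrobenzyl in place of 3-bromo-4-methylphenyl on an aromatic nitrogen with 4-nitrobenzyl in place of 3-bromo-4-methylphenyl on an aromatic nitrogen. Without a number for compound 2, the step cannot be sized exactly. A move towards stronger inhibition is expected, but only to a weak level like that of compound 1 at 182000 nM in this series. Compound 3 is estimated at 90000 nM with an expected range from 20000 nM to 350000 nM in this test.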

Compound 3, half-maximal inhibitory concentration: "not active" (no number reported)
Nothing numeric was reported for compound 3; no gap can be computed for the estimate.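

In this assay compound 3, like compound 2, has no number, so no step can be read between them, and no measured evidence bears on this result.

Still open, as far as these compounds go, is whether any group on that aromatic nitrogen gives stronger inhibition than compound 1 at 182000 nM does.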